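Methoxy to Chloro on a Shared Core: Expecting Another Limit

A few compounds are considered here, and "the series" means these few. Any claim that something is new, unique, unknown or untested is made for them only; others in the source may bear on it.

Compound 1 `Cc1ccc(S(=O)(=O)Oc2ccc3c(c2C)[C@H](Cn2cc(-c4ccc(Cl)cc4)nn2)[C@@]24CC(=O)[C@@](C)(CC[C@@H]32)C4)cc1` gives only a limit, > 20000 nM, in a functional assay on SMMC-7721 cells (Homo sapiens) for cytotoxicity, read by MTT assay, with a stated time of 4 days; a higher number here means a weaker inhibitor, a lower number a stronger inhibitor.
Compound 2 `C=C1C[C@]23C[C@@]1(O)CC[C@@H]2c1cccc(C)c1[C@@H]3Cn1cc(-c2ccc(OC)cc2)nn1` likewise gives only a limit, > 20000 nM, in this assay.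
Compound 3 `COc1ccc(-c2cn(C[C@H]3c4c(ccc(OS(=O)(=O)c5ccc(C)cc5)c4C)[C@@H]4CC[C@@]5(C)C[C@]43CC5=O)nn2)cc1` also gives only a limit, > 20000 nM, in this assay.

The change from compound 3 to compound 1 is chloro in place of methoxy on an aromatic carbon. Its size, a step that the two limits leave unreadable from compound 3 to compound 1, cannot be read because of the limit of > 20000 nM in this assay, at which 3 of the 3 values shown sit. Compound 4 `C=C1C[C@]23C[C@@]1(O)CC[C@@H]2c1cccc(C)c1[C@@H]3Cn1cc(-c2ccc(Cl)cc2)nn1` has not yet been measured; it differs from compound 2 by chloro in place of methoxy on an aromatic carbon, the same change. How the core of compound 2 differs from the core of compound 3 is not broken down here. Because the earlier step that the two limits leave unreadable from compound 3 to compound 1 gave no readable size and compound 2 itself sits only at a limit, the step from compound 2 to compound 4 is expected to be unreadable too, a step that the limit leaves unreadable from compound 2 to compound 4. Compound 4 is therefore estimated at 40000 nM, most likely reported as a limit once more.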

Compound 4, half-maximal inhibitory concentration: > 20000 nM
Compound 4: no number, only a limit (the forecaster's own chance of this, stated with the estimate: 85%); the middle value lies beyond the limit too.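

No size can be read for the change from compound 2 to compound 4, because neither compound gives a number: the limit of > 20000 nM in this assay, at which 4 of the 4 values shown sit.

The compounds shown leave open whether 4-chlorophenyl in place of 4-methoxyphenyl alters activity at all, and which structures related to these would give a measurable value.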